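A few compounds are considered here, and "the series" means these few. Any claim that something is new, unique, unknown or untested is made for them only; others in the source may bear on it.

Measured so far:
- Compound 1, `COc1cc(-c2cc(C(=O)O)c3ccccc3n2)ccc1OCC(=O)Nc1ccccc1`, gives 0.7 in a physicochemical assay for lipophilicity, using the shake flask method, in phosphate buffer, measured as octanol-water partition, at pH 7.4; on this read-out higher numbers stand for higher lipophilicity and lower numbers for lower lipophilicity.
- Compound 2, `COc1cc(-c2cc(C(=O)O)c3ccccc3n2)ccc1OCC(=O)Nc1ccc(C)cc1`, gives 1.2 in this assay.
- Compound 3, `COc1cc(-c2cc(C(=O)O)c3ccccc3n2)ccc1OCC(=O)Nc1ccc(C(F)(F)F)cc1`, gives 1.6 in this assay.

Compound 1 stands lowest of the three on this assay. Its nearest neighbour is compound 2, reached by a number 0.50 log units higher from compound 1 to compound 2 (beyond the scatter), and the furthest is compound 3, reached by a number 0.90 log units higher from compound 1 to compound 3 (beyond the scatter); between those two lies a number 0.40 log units higher from compound 2 to compound 3 (beyond the scatter). Each of these steps keeps the phenyl on the amide-type nitrogen and only changes what sits on that phenyl.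

Compound 4, `COc1cc(-c2cc(C(=O)O)c3ccccc3n2)ccc1OCC(=O)NCc1ccco1`, differs from compound 1 in a different way: (furan-2-yl)methyl in place of phenyl on an amide-type nitrogen. Among the compounds with values here, no measured step removes the phenyl itself, so the three steps do not bear directly on this change; they show only that adding a group onto the phenyl raised the number in this assay each time. With the phenyl gone and a five-membered ring with one hetero atom and one hydrogen-bond acceptor entering in its place, a modest step downward is expected, a number 0.60 log units lower from compound 1 to compound 4 (beyond the scatter). Compound 4 is therefore estimated at 0.1 in this assay, with a range from -0.5 to 0.7.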

Compound 4, distribution coefficient: -0.3
Beside the measured number, compound 4's estimate is 0.40 log units above it; measured number inside the range.
By their numbers in this assay, from the lowest: compound 4; then compound 1; then compound 2; then compound 3.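

In this assay, replacing the phenyl on the amide-type nitrogen with (furan-2-yl)methyl gives (a number 1.00 log units lower from compound 1 to compound 4 (beyond the scatter)), so this position can also lower the number, whereas the earlier changes on the phenyl only raised it. The gap widens when the replaced ring carries a group, with (a number 1.50 log units lower from compound 2 to compound 4 (beyond the scatter)) for 4-methylphenyl and (a number 1.90 log units lower from compound 3 to compound 4 (beyond the scatter)) for 4-(trifluoromethyl)phenyl, which leaves compound 4 the lowest of the four. Nothing measured here explains why the number fell.

The compounds shown leave open whether the drop follows the furan ring or the methylene link that comes with it, a question that a benzyl group on the same nitrogen would help separate. From the compounds shown here alone, it also remains open whether a methyl or trifluoromethyl group on the furan ring would raise the number as it did on the phenyl.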